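The source may report more compounds than this note shows. Statements on the series, on what has been measured and on what is new or still open speak of the compounds shown alone.

Three compounds share one core and differ only in the group on the carbon with a double bond to nitrogen. In a functional assay on HepG2 cells (Homo sapiens) for antiproliferative activity, read by MTT assay, with a stated time of 72 h (on this read-out higher numbers stand for weaker inhibition and lower numbers for stronger inhibition), compound 1 `O=C(N/N=C/c1cccc([N+](=O)[O-])c1)Nc1ccc(Oc2ccnc3[nH]ccc23)c(F)c1` gives 5180 nM, compound 2 `O=C(N/N=C/c1ccc(Cl)c(Cl)c1)Nc1ccc(Oc2ccnc3[nH]ccc23)c(F)c1` gives 3700 nM, and compound 3 `O=C(N/N=C/c1ccc(O)cc1)Nc1ccc(Oc2ccnc3[nH]ccc23)c(F)c1` gives 1950 nM. Compound 3 sits at the low end of these numbers: the measured steps to it are a 1.9-fold lower number from compound 2 to compound 3 (0.28 log units; within the scatter) and a 2.7-fold lower number from compound 1 to compound 3 (0.42 log units; beyond the scatter).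

Compound 4 `O=C(N/N=C/c1ccc(O)c(Br)c1)Nc1ccc(Oc2ccnc3[nH]ccc23)c(F)c1` adds one atom to compound 3: bromo in place of hydrogen on an aromatic carbon. This is bromo in place of hydrogen on an aromatic carbon, ortho to a hydroxy group, which makes 4-hydroxyphenyl into 3-bromo-4-hydroxyphenyl. For the measured compounds named here, no measured step adds a bromo. The closest guide is the 3,4-dichlorophenyl group of compound 2, with a 1.9-fold lower number from compound 2 to compound 3 (0.28 log units; within the scatter), and the other replacements were also small, such as a 1.4-fold lower number from compound 1 to compound 2 (0.15 log units; within the scatter). In this assay, no change beyond the scatter is therefore expected, only an estimated 1.2-fold higher number from compound 3 to compound 4 (0.09 log units; within the scatter). The estimate for compound 4 is 2400 nM, with an expected range of 1000 nM to 5500 nM.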

Compound 4, half-maximal inhibitory concentration: 1360 nM
Beside the measured number, compound 4's estimate is 1.8-fold (0.25 log units) above it; measured number inside the range.
By their numbers in this assay, from the lowest: compounds 4, 3, 2 and 1 (each within the scatter of the next, the first and the last beyond it).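

In this assay, a bromo can sit ortho to a hydroxy group without moving the number beyond the scatter: a 1.4-fold lower number from compound 3 to compound 4 (0.16 log units; within the scatter). Yet 3-bromo-4-hydroxyphenyl stands clear of both earlier groups, with a 2.7-fold lower number from compound 2 to compound 4 (0.43 log units; beyond the scatter) and a 3.8-fold lower number from compound 1 to compound 4 (0.58 log units; beyond the scatter), whereas 4-hydroxyphenyl stood clear of 3-nitrophenyl only. No measurement shown here explains these differences. The compounds shown leave open whether an amine in place of the bromo, or a methoxy group in place of the hydroxy group, would keep these numbers.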